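This account rests on a few compounds, and the source may have more. Where it says the series, first, only, none or still open, it means among the compounds named here.

In an ADME assay on microsomes from liver (Rattus norvegicus) for metabolic stability, using NADPH (a higher number here means faster removal of the compound, a lower number slower removal), compound 1 `Nc1cc(C(F)(F)F)c(Br)nc1C(=O)NCCC(F)(F)F` gives 0.0558 mL/min/kg and compound 2 `Nc1cc(C(F)(F)F)c(Br)nc1C(=O)NC[C@H](O)C(F)(F)F` gives 0.023 mL/min/kg, so compound 2 holds the lower of the two numbers. Compound 3 `Nc1cc(C(F)(F)F)c(Br)nc1C(=O)NC[C@@H](O)C(F)(F)F` has not been measured yet, and its structure relates to compound 2 in one way: the two compounds have the same atoms and bonds and differ only in configuration as drawn: 1 of 1 stereo elements differ; a stereocentre at a saturated chain carbon is drawn S in compound 2 and R in compound 3. Within the data shown here, only one measured step offers any guide, the placing of hydroxy in place of hydrogen on a saturated chain carbon, and that step, a 2.4-fold lower number from compound 1 to compound 2 (0.38 log units; beyond the scatter), is modest. Among the measured compounds shown here, no measured pair shows what a change of configuration alone does. Compound 3 keeps the hydroxy, so it is expected to stay close to compound 2, with no firm direction and probably no step beyond the scatter. The expected change is a 1.3-fold higher number from compound 2 to compound 3 (0.12 log units; within the scatter). For compound 3 the estimated clearance is 0.03 mL/min/kg, with an expected range from 0.012 mL/min/kg to 0.07 mL/min/kg.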

Compound 3, clearance in the Rattus norvegicus assay: 0.0371 mL/min/kg
Estimate against measurement, compound 3: 1.2-fold (0.09 log units) below; the range from low to high includes it.
By their numbers in the Rattus norvegicus assay, from the lowest: compounds 2, 3 and 1 (each within the scatter of the next, the first and the last beyond it).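

In the Rattus norvegicus assay compound 2 gives 0.023 mL/min/kg and compound 3 gives 0.0371 mL/min/kg, and the swap of configuration at the saturated chain carbon gives a 1.6-fold higher number from compound 2 to compound 3 (0.21 log units; within the scatter) and so shows no readable effect at this position. The hydroxy step in the Rattus norvegicus assay also depends on the configuration drawn: a 2.4-fold lower number from compound 1 to compound 2 (0.38 log units; beyond the scatter) lay beyond the scatter, but a 1.5-fold lower number from compound 1 to compound 3 (0.18 log units; within the scatter) does not, so the first step does not hold for both configurations. In a physicochemical assay for solubility, at pH 6.8 (on this read-out higher numbers stand for higher solubility and lower numbers for lower solubility), compound 2 gives 290 ug/mL and compound 3 gives 177 ug/mL, and the same swap gives a 1.6-fold lower number from compound 2 to compound 3 (0.21 log units; within the scatter), again no readable difference, and the pair isolates a single structural contrast: the fact that compounds 2 and 3 differ only in the configuration as drawn.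

On these data alone, it remains open whether an amine or a methoxy group on this carbon, in either configuration, would move the number in the Rattus norvegicus assay beyond the scatter. As far as these compounds go, it is also open whether a longer chain carrying the hydroxy would keep these numbers.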